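The source may report more compounds than this note shows. Statements on the series, on what has been measured and on what is new or still open speak of the compounds shown alone.

Measured compounds, cytotoxicity in an ADME assay on THP-1 cells (Homo sapiens) for cytotoxicity; a lower number here means a stronger inhibitor, a higher number a weaker inhibitor:
- compound 1 `COc1ccccc1-c1nnc(-c2ccc(C(=O)N/N=C/c3cc(O)ccc3O)cc2)o1`: 100000 nM
- compound 2 `COc1ccccc1-c1nnc(-c2ccc(C(=O)N/N=C/c3ccccc3F)cc2)o1`: 313000 nM
- compound 3 `COc1ccccc1-c1nnc(-c2ccc(C(=O)N/N=C/c3ccc(Cl)cc3Cl)cc2)o1`: 78800 nM

Compound 3 holds the lowest of the three numbers in this assay. The step of a 1.3-fold lower number from compound 1 to compound 3 (0.10 log units; within the scatter) lies within the scatter, so compound 1 and compound 3 cannot be told apart; against compound 2 the difference is clear, a 4.0-fold lower number from compound 2 to compound 3 (0.60 log units; beyond the scatter).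

Compound 4 `COc1ccccc1-c1nnc(-c2ccc(C(=O)N/N=C/c3ccccc3[N+](=O)[O-])cc2)o1` differs from compound 3 only at the carbon with a double bond to nitrogen: 2-nitrophenyl in place of 2,4-dichlorophenyl on a carbon with a double bond to nitrogen. Among the compounds with values here, no measured step swaps in a nitro group, so the bearing steps are only those at the same position: a 3.1-fold higher number from compound 1 to compound 2 (0.50 log units; beyond the scatter) and a 4.0-fold lower number from compound 2 to compound 3 (0.60 log units; beyond the scatter), both modest and in opposite directions. Three phenyl variants span only a narrow range, all at very weak inhibition. The expectation is therefore for compound 4 a step of a 1.5-fold higher number from compound 3 to compound 4 (0.18 log units; within the scatter), most likely within the scatter or slightly upward. The estimate for compound 4 in this assay is 120000 nM, with a range from 50000 nM to 300000 nM.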

Compound 4, half-maximal inhibitory concentration: 161000 nM
Compound 4: the middle estimate sits 1.3-fold (0.13 log units) below what was measured; measured number inside the range.
By their numbers in this assay, from the lowest: compounds 3, 1, 4 and 2 (each within the scatter of the next, the first and the last beyond it).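

In this assay, 2-nitrophenyl on the carbon with a double bond to nitrogen separates from 2,4-dichlorophenyl (a 2.0-fold higher number from compound 3 to compound 4 (0.31 log units; beyond the scatter)), but it cannot be told apart from 2-fluorophenyl (a 1.9-fold lower number from compound 2 to compound 4 (0.29 log units; within the scatter)) or from 2,5-dihydroxyphenyl (a 1.6-fold higher number from compound 1 to compound 4 (0.21 log units; within the scatter)). Nitro in place of fluoro on an aromatic carbon therefore gives no readable change here, and compound 4 lies within the scatter of both compound 1 and compound 2, even though those two are clearly apart. No measurement available here accounts for these differences.

From the compounds shown here alone, whether an amine or a carboxylic acid on this phenyl ring would keep the number in the same weak range remains open. Also open, going by these compounds, is whether a single chlorine would match 2,4-dichlorophenyl.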